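Benzyl for Methoxycarbonyl: Cytotoxicity Outlook for Compound 4

The compounds below may be only part of what the source reports. "The series", "measured", "known", "first", "only" and "open" are said of these compounds alone.

Compound 1 `COC(=O)c1cccc(NC(=O)C2CCCN(C(=O)c3cc(C(F)(F)F)cc(C(F)(F)F)c3)C2)c1` was tested in an ADME assay on PC-3 cells (Homo sapiens) for cytotoxicity, read by WST assay, tested at 100 uM (on this read-out lower numbers stand for less inhibition and higher numbers for more inhibition at the one concentration tested (going by the name of the read-out)), and gives 0%. Compound 2 `CSc1cccc(C(=O)N2CCCC(C(=O)Nc3ccc(Cl)cc3)C2)c1` gives 0%, and compound 3 `N#Cc1cccc(C(=O)N2CCCC(C(=O)Nc3ccc(Cl)cc3)C2)c1` gives 0%. Among the measured compounds shown here, the one measured step, no change at the digits printed from compound 2 to compound 3 (within the scatter), brought no movement beyond the scatter. Compound 1 thus stands level with compounds 2 and 3, with all three at the floor of this read-out.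

Compound 4 `O=C(Nc1cccc(Cc2ccccc2)c1)C1CCCN(C(=O)c2cc(C(F)(F)F)cc(C(F)(F)F)c2)C1` differs from compound 1 in one place: benzyl in place of methoxycarbonyl on an aromatic carbon. For the measured compounds named here, no measured step touches this position, so the only guide is that every change so far left the read-out flat. The step of no change at the digits printed from compound 1 to compound 4 (within the scatter) is therefore expected to stay within the scatter. Compound 4 is expected to give 0%, within a range from 0% to 15%.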

Compound 4, a percentage reported as inhibition, at one concentration (the size of the read-out at that concentration, not a potency): 0%
For compound 4 middle estimate and measured number coincide at the digits printed; the measured number falls inside the stated range.
By their numbers in this assay, from the lowest: compounds 1, 2, 3 and 4 (each within the scatter of the next).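

At this position, on an aromatic carbon meta to a large group, replacing methoxycarbonyl with benzyl gives no change at the digits printed from compound 1 to compound 4 (within the scatter) in this assay. The earlier compounds shown here offered no step here, and this one shows that exchanging a group with hydrogen-bond acceptors and no ring for a larger one with an aromatic ring and no such acceptors leaves the read-out unmoved. Nothing available bears on why this is so. The compounds shown leave open whether an amine or a carboxylic acid on this carbon would move the read-out.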